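A few compounds are considered here, and "the series" means these few. Any claim that something is new, unique, unknown or untested is made for them only; others in the source may bear on it.

Measured so far:
Compound 1 `COC(=O)c1ccccc1-c1cnc(C(=O)CCCCCCc2ccccc2)o1` gives 60 nM in an assay (Rattus norvegicus) for inhibition of Fatty-acid amide hydrolase 1 (Homo sapiens); a higher number here means a weaker inhibitor, a lower number a stronger inhibitor.
Compound 2 `O=C(CCCCCCc1ccccc1)c1ncc(-c2cccc(O)c2)o1` gives 50 nM in this assay.
Compound 3 `COC(=O)c1ccc(-c2cnc(C(=O)CCCCCCc3ccccc3)o2)cc1` gives 40 nM in this assay.

The three measured compounds share one core and differ only in the aromatic group attached to it. Their numbers lie close together: compound 2 sits in the middle of the three, and its distance to compound 1 and to compound 3 is each within the usual scatter of repeated measurements, so the three compounds cannot be told apart on these data. Whatever the group on that aromatic carbon carries, whether an ester or a hydroxyl, the number in this assay stays in the same narrow band.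

Compound 4 `Cc1cccnc1-c1cnc(C(=O)CCCCCCc2ccccc2)o1` is the next step from compound 2. The change is 3-methylpyridin-2-yl in place of 3-hydroxyphenyl on an aromatic carbon. The hydrogen-bond donor of compound 2 is lost, and a ring nitrogen comes in with a methyl group.

Because the three measured groups all land near 50 nM, the expected step from compound 2 to compound 4 is small, a 1.6-fold higher number from compound 2 to compound 4 (0.20 log units; within the scatter), leaning slightly towards a weaker inhibitor but likely within the scatter. Compound 4 is therefore expected to give about 80 nM in this assay, with a range from 25 nM to 250 nM.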

Compound 4, inhibition constant: 15 nM
For compound 4 the middle estimate is 5.3-fold (0.73 log units) above the measured one, outside the stated range (below it).
By their numbers in this assay, from the lowest: compound 4; then compounds 3, 2 and 1 (each within the scatter of the next).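

For the compounds shown here, putting 3-methylpyridin-2-yl in place of 3-hydroxyphenyl gives a 3.3-fold lower number from compound 2 to compound 4 (0.52 log units; beyond the scatter) in this assay, so the number does respond to the group at this aromatic carbon, despite the narrow band of the earlier compounds. The hydrogen-bond donor of 3-hydroxyphenyl is not needed for a low number here, as compound 4 has no donor in this group and is the stronger inhibitor of the pair. Nothing among the data shown explains the step.

Going by these compounds, the ring nitrogen and the methyl group enter together, so it remains open which of them accounts for the change, or whether both are needed. A pyridine ring without the methyl group, or a methylphenyl group, would separate the two.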